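The source may hold more compounds than are shown below. What is called first, only, known or untested is meant among the compounds shown, and "the series" means these compounds.

Compound 1 `Cc1ncnc2c1c(I)cn2[C@@H]1O[C@H](CO)[C@@H](O)[C@H]1O`: 3460 nM
Compound 2 `Cc1nc(N)c2c(-c3ccccc3)cn([C@@H]3O[C@H](CO)[C@@H](O)[C@H]3O)c2n1`: > 20000 nM
Compound 3 `Cc1nc(N)c2c(-c3ccco3)cn([C@@H]3O[C@H](CO)[C@@H](O)[C@H]3O)c2n1`: > 20000 nM

All three were tested in a functional assay on HepG2 cells (Homo sapiens) for antiproliferative activity, read by XTT assay, with a stated time of 72 h; on this read-out higher numbers stand for weaker inhibition and lower numbers for stronger inhibition. Among the measured compounds shown here, compound 1 gives 3460 nM, the only plain number among the three values. For compound 2 the value > 20000 nM is a limit of this assay and not a number. For compound 3 the value > 20000 nM is likewise a limit. For the measured compounds named here, the only step between measured neighbours, a step that the two limits leave unreadable from compound 2 to compound 3, is thus unreadable in size.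

The unmeasured compound 4 `Cc1ncnc2c1c(-c1ccoc1)cn2[C@@H]1O[C@H](CO)[C@@H](O)[C@H]1O` arises from compound 1 by the change (furan-3-yl in place of iodo on an aromatic carbon). Going by the values given here, no measured step follows this exact change, and compounds 2 and 3 also differ from compound 1 in their core, so they give only indirect guidance. What stands out is the limit of > 20000 nM in this assay, at which 2 of the 3 values shown sit: both compounds that carry an aromatic ring on an aromatic carbon of their core sit at that limit, while compound 1 with iodo gives a number. On this basis compound 4 is expected to be weaker than compound 1, and the step of a 2.9-fold higher number from compound 1 to compound 4 (0.46 log units; beyond the scatter) is the estimate, held with wide uncertainty. The estimate for compound 4 in this assay is 10000 nM, expected to fall between 3000 nM and 30000 nM, with a real chance that only a limit is reported.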

Compound 4, half-maximal inhibitory concentration: 5320 nM
Beside the measured number, compound 4's estimate is 1.9-fold (0.27 log units) above it; the measured number falls inside the stated range.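

In this assay, putting furan-3-yl, a five-membered aromatic ring of 5 heavy atoms, in place of iodo, a single heavy atom, on this aromatic carbon gives a 1.5-fold higher number from compound 1 to compound 4 (0.19 log units; within the scatter). Among the compounds shown here, on the core of compound 1, then, this position accepts an aromatic ring with no readable loss of antiproliferative activity, something the earlier compounds could not show. Compound 2 and compound 3 also carry an aromatic ring on an aromatic carbon of their core and stand at a limit rather than a number, but their core differs from that of compound 4, so the aromatic ring alone cannot be tied to that limit: the limit of > 20000 nM in this assay, at which 2 of the 4 values shown sit.

On these data alone, the step between compound 2 and compound 3 cannot be read, which leaves phenyl and furan-2-yl unranked, and it remains open how either would behave on the core of compound 1. For the compounds shown here, also open is what an amine, a carboxylic acid or a longer alkyl chain would give on this aromatic carbon, since iodo and furan-3-yl are the only groups compared there on this core.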